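The compounds below may be only part of what the source reports. "The series", "measured", "known", "first", "only" and "open" are said of these compounds alone.

The measured compounds:
compound 1, `COc1nc(N)nc2c1c(-c1ccco1)cn2[C@@H]1O[C@H](CO)[C@@H](O)[C@H]1O`: > 20000 nM
compound 2, `O=c1[nH]cnc2c1c(-c1ccccc1)cn2[C@@H]1O[C@H](CO)[C@@H](O)[C@H]1O`: > 20000 nM
compound 3, `COc1ncnc2c1c(-c1ccco1)cn2[C@@H]1O[C@H](CO)[C@@H](O)[C@H]1O`: 380 nM

In a functional assay on K562 cells (Homo sapiens), read by MTT assay, with a stated time of 72 h (on this read-out higher numbers stand for weaker inhibition and lower numbers for stronger inhibition), compound 3 gives 380 nM. For compound 1 this assay gives only a limit, > 20000 nM. For compound 2 this assay likewise gives only a limit, > 20000 nM. The change from compound 3 to compound 1 is amino in place of hydrogen on an aromatic carbon; it gives an at least 52-fold higher number from compound 3 to compound 1 (1.72 log units; beyond the scatter), and how far it really reaches cannot be told because of the limit of > 20000 nM in this assay, at which 2 of the 3 values shown sit. The unmeasured compound 4, `Nc1nc2c(c(-c3ccccc3)cn2[C@@H]2O[C@H](CO)[C@@H](O)[C@H]2O)c(=O)[nH]1`, carries the same kind of change relative to compound 2: amino in place of hydrogen on an aromatic carbon; the surroundings differ in that the new group stands meta to a group of 1 heavy atom rather than meta to a methoxy group (2 heavy atoms). The difference between the cores of compound 2 and compound 3 is not broken down here. The expectation for compound 4 rests on the direction of an at least 52-fold higher number from compound 3 to compound 1 (1.72 log units; beyond the scatter) and on the fact that compound 2 is reported only as a limit, so a weakening at most and no gain is expected. Compound 4 is therefore expected near 60000 nM, most likely reported only as a limit. The expected step is a step that the limit leaves unreadable from compound 2 to compound 4.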

Compound 4, half-maximal inhibitory concentration: > 20000 nM
Compound 4 ended at the assay's limit (the forecaster's own chance of this, stated with the estimate: 90%); the middle value does not contradict the limit.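

No step from compound 2 to compound 4 can be read, because both are reported only as a limit: the limit of > 20000 nM in this assay, at which 3 of the 4 values shown sit.

The compounds shown leave open whether amino in place of hydrogen changes the activity of compound 2 at all, and how weak compound 1, compound 2 and compound 4 really are in this assay.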